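This account rests on a few compounds, and the source may have more. Where it says the series, first, only, none or still open, it means among the compounds named here.

Compound 1 `COc1cc(N2C(N)=C(C#N)C(c3ccc([N+](=O)[O-])cc3)C3=C2CC(C)(C)CC3=O)cc(OC)c1OC` gives 70% in a functional assay on Ehrlich cells (Mus musculus) for cytotoxicity, tested at 50 ug/mL; a lower number here means a weaker effect, a higher number a stronger effect of the compound at the concentration tested. Compound 2 `COc1cc(N2C(N)=C(C#N)C(/C=C/c3ccccc3)C3=C2CC(C)(C)CC3=O)cc(OC)c1OC` gives 30%. Compound 3 `COc1ccccc1C1C(C#N)=C(N)N(c2cc(OC)c(OC)c(OC)c2)C2=C1C(=O)CC(C)(C)C2` gives 70%.

Compound 2 stands lowest of the three numbers: a number 40 percentage points lower from compound 1 to compound 2 (beyond the scatter) and a number 40 percentage points higher from compound 2 to compound 3 (beyond the scatter) both separate it from the other two compounds by a large margin, beyond the scatter, while compound 1 and compound 3 lie within the scatter of each other (no change at the digits printed from compound 1 to compound 3 (within the scatter)).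

Compound 4 `COc1cc(N2C(N)=C(C#N)C(c3cccs3)C3=C2CC(C)(C)CC3=O)cc(OC)c1OC` differs from compound 2 in one place: thiophen-2-yl in place of 2-phenylethenyl on a saturated ring carbon. Among the compounds with values here, no measured pair swaps the 2-phenylethenyl for a thiophen-2-yl, so the nearest guide is the step in which the 2-phenylethenyl is replaced by an aromatic ring on the same saturated ring carbon, a number 40 percentage points higher from compound 2 to compound 3 (beyond the scatter), a large rise; a number 40 percentage points lower from compound 1 to compound 2 (beyond the scatter) points the same way, the aromatic ring giving the higher number. On that basis a large rise is expected for compound 4, a number 35 percentage points higher from compound 2 to compound 4 (beyond the scatter), in this assay. Compound 4 is therefore estimated at 65%, with a range from 45% to 85%.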

Compound 4, a percentage reported as activity, at one concentration (the size of the read-out at that concentration, not a potency): 15%
The estimate for compound 4 lay 50 percentage points above the measured number; measured number outside the range, below it.
By their numbers in this assay, from the lowest: compound 4; then compound 2; then compounds 1 and 3 (each within the scatter of the next).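

At this saturated ring carbon, an aromatic ring alone does not secure the higher number in this assay: the read-out shows a number 55 percentage points lower from compound 3 to compound 4 (beyond the scatter) and a number 55 percentage points lower from compound 1 to compound 4 (beyond the scatter) when thiophen-2-yl takes the place of the six-membered aromatic rings with their substituents. The 2-phenylethenyl group, until now the low end of the series, also no longer marks the bottom, with a number 15 percentage points lower from compound 2 to compound 4 (beyond the scatter) as a modest step, so compound 4 now stands lowest of the four. Nothing reported here explains why this five-membered aromatic ring behaves so differently from the other groups.

The compounds shown leave open whether the fall goes with the sulfur or with the smaller ring, which a furan-2-yl or an unsubstituted phenyl on the same carbon would help separate. Also open, as far as these compounds go, is how a ring carrying an amine or a carboxylic acid would read here.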